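The source may report more compounds than this note shows. Statements on the series, on what has been measured and on what is new or still open speak of the compounds shown alone.

Measured so far in an assay on isolated protein for inhibition of Alpha glucosidase (Homo sapiens), with stated times of 5 min and 15 min, tested at 50 uM; a lower number here means less inhibition, a higher number more inhibition at the concentration tested (going by the name of the read-out):
compound 1, `O=C1/C(=C/c2ccccc2)CCC/C1=C\c1ccc(O)cc1`: 53%
compound 2, `O=C1/C(=C/c2ccccc2)CCC/C1=C\c1ccc(F)cc1`: 34%
compound 3, `Cc1ccc(/C=C2\CCC/C(=C\c3ccccc3)C2=O)cc1`: 34.1%

Compound 3 stands second highest of the three numbers in this assay. Its nearest neighbour is compound 2, and the step of a number 0.1 percentage points higher from compound 2 to compound 3 (within the scatter) lies within the scatter, so compounds 2 and 3 are not separated by these numbers. Its furthest neighbour is compound 1; the step of a number 18.9 percentage points lower from compound 1 to compound 3 (beyond the scatter) is beyond the scatter, as is the matching step a number 19 percentage points lower from compound 1 to compound 2 (beyond the scatter), so compound 1 sits apart from compounds 2 and 3.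

Compound 4, `O=C1/C(=C/c2ccccc2)CCC/C1=C\c1cccc(F)c1`, is not yet measured. Relative to compound 3 the change is 3-fluorophenyl in place of 4-methylphenyl on a double-bonded chain carbon bound to a double-bonded ring carbon. For the measured compounds named here, no measured step moves a fluorine from one ring carbon to another. Going by the values given here, the only step bearing directly on a fluoro-for-methyl exchange is a number 0.1 percentage points higher from compound 2 to compound 3 (within the scatter), which was within the scatter, and the two steps away from compound 1 were modest and of the same size. Compounds 2 and 3 therefore look interchangeable on these numbers, and a fluorine on another ring carbon is expected to land near them, so from compound 3 no step beyond the scatter is expected, a number 0.9 percentage points higher from compound 3 to compound 4 (within the scatter). Compound 4 is expected to give 35% in this assay, with a range from 20% to 50%.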

Compound 4, a percentage reported as inhibition, at one concentration (the size of the read-out at that concentration, not a potency): 39.8%
Compound 4: middle estimate off by 4.8 percentage points, on the low side; low and high end bracket the measured number.
By their numbers in this assay, from the lowest: compounds 2, 3 and 4 (each within the scatter of the next); then compound 1.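

In this assay, for the compounds shown here, the first reading of a fluorine on another ring carbon, 3-fluorophenyl in place of 4-fluorophenyl, gives a number 5.8 percentage points higher from compound 2 to compound 4 (within the scatter), and 3-fluorophenyl in place of 4-methylphenyl gives a number 5.7 percentage points higher from compound 3 to compound 4 (within the scatter), so at this place on the double-bonded chain carbon these numbers do not separate the three groups. The exchange of 4-hydroxyphenyl for 3-fluorophenyl gives a number 13.2 percentage points lower from compound 1 to compound 4 (beyond the scatter), so compound 1, with its 4-hydroxyphenyl, now stands apart from three compounds carrying no hydroxy, and a fluorine on this other ring carbon does not close that gap. Nothing available bears on why these groups read as they do.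

Still open, going by these compounds, is whether the number of compound 1 belongs to hydroxy itself or would also come with an amine or a carboxylic acid on the same aromatic carbon, and whether a hydroxy on another ring carbon would keep it. Each reading also comes from a single concentration, so the percentages give no potency for any of these groups, and a methoxy or a longer chain at this place remains unplaced.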